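This account rests on a few compounds, and the source may have more. Where it says the series, first, only, none or still open, it means among the compounds named here.

Compounds that share one core, and differ only in their fluoro groups, have been tested in a functional assay (aorta) for inhibition, with Rattus norvegicus as the target; on this read-out higher numbers stand for an effect only at larger amounts of compound and lower numbers for an effect already at smaller amounts. Compound 1 `O=C1C(Nc2ccc(F)cc2)=CC(=O)c2ncccc21` gives 541 nM, compound 2 `O=C1C(Nc2ccc(F)c(F)c2)=CC(=O)c2ncccc21` gives 251 nM, and compound 3 `O=C1C(Nc2ccc(F)cc2F)=CC(=O)c2ncccc21` gives 288 nM. Compound 3 cannot be clearly separated from either of the others: its value lies within the usual scatter of the value of compound 2, and a 1.9-fold lower number from compound 1 to compound 3 (0.27 log units; within the scatter) is also within the scatter.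

Compound 4 `O=C1C(Nc2ccc(F)c(F)c2F)=CC(=O)c2ncccc21` has not yet been measured. It differs from compound 3 by a single change, fluoro in place of hydrogen on an aromatic carbon, ortho to two fluoro groups and meta to a large group.

Two measured steps make the same kind of swap. One is a 2.2-fold lower number from compound 1 to compound 2 (0.33 log units; beyond the scatter), which is modest and just beyond the scatter, and the other is a 1.9-fold lower number from compound 1 to compound 3 (0.27 log units; within the scatter). Both point towards a lower number, but both start from compound 1, and neither adds a fluoro ortho to two fluoro groups, so they offer only a rough guide. A small downward shift is therefore expected in this assay, with an estimated 1.5-fold lower number from compound 3 to compound 4 (0.18 log units; within the scatter). For compound 4 the estimated value is 190 nM, with an expected range from 85 nM to 420 nM.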

Compound 4, half-maximal effective concentration: 937 nM
Compound 4: the middle estimate sits 4.9-fold (0.69 log units) below what was measured; measured number above the stated range.
By their numbers in this assay, from the lowest: compounds 2, 3, 1 and 4 (each within the scatter of the next, the first and the last beyond it).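

The fluoro group that enters ortho to two fluoro groups and meta to a large group does not continue the earlier downward trend in this assay: it gives a 3.3-fold higher number from compound 3 to compound 4 (0.51 log units; beyond the scatter), and the other route to the same compound gives a 3.7-fold higher number from compound 2 to compound 4 (0.57 log units; beyond the scatter). Swapping hydrogen for fluoro on this ring therefore has no fixed effect, and the step to the third fluoro group differs from the earlier step to a second one by more than the scatter of two such steps: the same change on two cores in this assay, a 2.2-fold lower number (0.33 log units; beyond the scatter) from compound 1 to compound 2 and a 3.3-fold higher number (0.51 log units; beyond the scatter) from compound 3 to compound 4, 7.0-fold (0.85 log units) apart, beyond the scatter of two such steps. The second pairing of steps, which also ends at compound 4, shows the same reversal: the same change on two cores in this assay, a 1.9-fold lower number (0.27 log units; within the scatter) from compound 1 to compound 3 and a 3.7-fold higher number (0.57 log units; beyond the scatter) from compound 2 to compound 4, 7.0-fold (0.85 log units) apart, beyond the scatter of two such steps.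

The compounds shown cannot separate the effect of this one carbon from the effect of the total number of fluoro groups on the ring, so it remains unclear which of the two drives the higher number for compound 4. They also leave open how a chloro group, a methoxy group or an amine would behave on this same carbon, since only hydrogen and fluoro are compared here.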